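This account rests on a few compounds, and the source may have more. Where it says the series, first, only, none or still open, it means among the compounds named here.

Measured so far:
Compound 1 `CCCCN1C(=O)NC2(CC2(C)C)C1=O`: 30%
Compound 2 `CC1(C)CC12NC(=O)N(c1ccccc1)C2=O`: 20%

In a functional assay on the whole organism for inhibition, with Mus musculus as the target, at a dose of 20 mg/kg by the oral route (on this read-out higher numbers stand for a stronger effect at the one dose given and lower numbers for a weaker effect), compound 1 gives 30% and compound 2 gives 20%. Compound 2 stands at the lower of the two numbers shown, but the gap to compound 1 lies within the usual scatter, so the two cannot be told apart. Compound 3 `CC1(C)CC12NC(=O)N(c1ccc(F)cc1)C2=O` has not yet been measured in this assay. It differs from compound 2 by fluoro in place of hydrogen on an aromatic carbon. Within the data shown here, no measured pair here shows what such a change does, so nothing beyond the scatter is expected in this assay. The step from compound 2 to compound 3 is expected to be a number 5 percentage points higher from compound 2 to compound 3 (within the scatter). Compound 3 is therefore expected to give about 25%, within a range from 10% to 45%.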

Compound 3, a percentage reported as inhibition, in the whole organism at one dose (the size of the read-out at that dose, not a potency): 30%
Compound 3: middle estimate off by 5 percentage points, on the low side, within the range that was stated.
By their numbers in this assay, from the lowest: compounds 2, 1 and 3 (each within the scatter of the next).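

In this assay, putting fluoro in place of hydrogen on an aromatic carbon, para to a large group, gives a number 10 percentage points higher from compound 2 to compound 3 (within the scatter), so this one swap cannot be told apart from repeat-to-repeat variation. This is the first pair shown that differs in one place on this ring, and it gives no sign that fluoro at this position changes the read-out. Nothing measured here bears on the reason for this result. As far as these compounds go, whether an amine or a carboxylic acid at the same position would move the number beyond the scatter remains open. Fluoro at other carbons of the ring also remains untested in the compounds shown.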